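Swapping a naphthyl for a tert-butylphenyl on the amine side

The source may hold more compounds than are shown below. What is called first, only, known or untested is meant among the compounds shown, and "the series" means these compounds.

Three compounds share a sulfonamide head joined through a flexible chain to a benzylic amine, and all three were tested in a functional assay on MIA PaCa-2 cells (Homo sapiens) for inhibition, read by MTT assay, with a stated time of 72 h; a higher number here means a weaker inhibitor of growth, a lower number a stronger inhibitor of growth. Compound 1 `Cc1ccc(C)c(S(=O)(=O)NCCCCCCNCc2ccc(Br)cc2)c1` gives 12000 nM. Compound 2 `O=S(=O)(NCCCNCc1cccc2ccccc12)c1cc(C(F)(F)F)cc(C(F)(F)F)c1` gives 2800 nM, the lowest of the three numbers; its distance to compound 1 and to compound 3 is in each case beyond the usual scatter, so compound 2 is the strongest growth inhibitor measured here. Compound 3 `CC(C)(C)c1ccc(CNCCNS(=O)(=O)c2cc(C(F)(F)F)cc(C(F)(F)F)c2)cc1` gives 15000 nM.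

The unmeasured compound 4 `CC(C)(C)c1ccc(CNCCCNS(=O)(=O)c2cc(C(F)(F)F)cc(C(F)(F)F)c2)cc1` keeps the whole of compound 2 except one change: 4-(tert-butyl)phenyl in place of naphthalen-1-yl on a saturated chain carbon bound to an amine nitrogen. Compound 3 carries the same 4-(tert-butyl)benzyl group on a shorter chain and shows a high number in this assay, while compound 2 with the naphthalen-1-yl group shows the low one. Among the measured compounds shown here, no single-change step among the measured compounds isolates this swap. The expected step from compound 2 to compound 4 is a 2.0-fold higher number from compound 2 to compound 4 (0.29 log units; within the scatter), towards a weaker inhibitor. Compound 4 is therefore estimated at 5500 nM, within a range of 2200 nM to 14000 nM.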

Compound 4, concentration for 50% growth inhibition: 2300 nM
The estimate for compound 4 lay 2.4-fold (0.38 log units) above the measured number; the measured number falls inside the stated range.
By their numbers in this assay, from the lowest: compounds 4 and 2 (each within the scatter of the next); then compounds 1 and 3 (each within the scatter of the next).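

In this assay, putting 4-(tert-butyl)phenyl in place of naphthalen-1-yl on a saturated chain carbon bound to an amine nitrogen gives a 1.2-fold lower number from compound 2 to compound 4 (0.09 log units; within the scatter), so the assay does not separate these two groups at this position, although one has two six-membered aromatic rings and the other has one. The high number of compound 3, 15000 nM, therefore does not follow from the 4-(tert-butyl)benzyl group alone, since compound 4 carries the same group on a different chain and gives 2300 nM. No measurement at hand explains why the two groups read alike.

As far as these compounds go, it remains open whether a saturated ring such as cyclohexyl, or a pyridine ring, would be tolerated in the same place. A longer chain between the sulfonamide and the amine of compound 4 is also an open question.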